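A Larger Bicyclic Amine on the Shared Core

The source may hold more compounds than are shown below. What is called first, only, known or untested is meant among the compounds shown, and "the series" means these compounds.

Compound 1 `O=C(CCc1ccc(C(F)(F)F)cc1)Nc1ccc2nc(N3CCC3)ccc2c1` carries an azetidin-1-yl group on the shared core. For the measured compounds named here, in an assay on isolated protein for displacement of a labelled ligand from melanin-concentrating hormone receptor 1 (Homo sapiens) (a higher number here means a weaker inhibitor, a lower number a stronger inhibitor), compound 1 gives 4 nM, the only single value recorded for it. Compound 2 `O=C(CCc1ccc(C(F)(F)F)cc1)Nc1ccc2nc(N3CCCC3)ccc2c1` is close in structure and in this assay compound 2 gives 3 nM; 3 nM (2 entries) in two separate entries, within the usual scatter of compound 1.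

Compound 3 `O=C(CCc1ccc(C(F)(F)F)cc1)Nc1ccc2nc(N3CC4CCC3CC4)ccc2c1` replaces the small ring of compound 1 with a larger one: a group of 8 heavy atoms (7 carbon, 1 nitrogen; 2 six-membered non-aromatic rings with 1 hetero atom each) in place of a group of 4 heavy atoms (3 carbon, 1 nitrogen; one four-membered non-aromatic ring with 1 hetero atom), on an aromatic carbon. Going by the values given here, no measured pair in this set shows the effect of such a change, so the expectation rests on the closeness of compound 1 and compound 2, which suggests this position tolerates some variation. The step from compound 1 to compound 3 is expected to be small, likely toward weaker binding if anything, a 2.0-fold higher number from compound 1 to compound 3 (0.30 log units; within the scatter). Compound 3 is therefore estimated at 8 nM, with a range from 2 nM to 40 nM.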

Compound 3, half-maximal inhibitory concentration: 3 nM
For compound 3 the middle estimate is 2.7-fold (0.43 log units) above the measured one, and the stated range covers the measured number.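

In this assay, replacing the azetidin-1-yl group of compound 1 with the larger group of compound 3 gives a small step (a 1.3-fold lower number from compound 1 to compound 3 (0.12 log units; within the scatter)), so the two compounds cannot be told apart. This position, on an aromatic carbon next to the ring nitrogen, therefore accepts a group of 8 heavy atoms with 2 six-membered non-aromatic rings in place of one of 4 heavy atoms with a single four-membered ring, at least in this one example. Nothing measured here explains why the larger group is accepted.

On these data alone, it remains open how an open-chain dimethylamino group or a piperazine ring, with its second nitrogen, would behave at this same carbon. The compounds shown also leave open what happens elsewhere on the shared core, for example if a nitrile replaces the trifluoromethyl group.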